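Trifluoromethylphenyl urea weighed against its dichlorophenyl parent

This account rests on a few compounds, and the source may have more. Where it says the series, first, only, none or still open, it means among the compounds named here.

Compound 1 `O=C(Nc1cccc(-n2cc(-c3ccncc3)c(-c3ccc(Cl)c(O)c3)n2)c1)Nc1ccc(Cl)c(Cl)c1` gives the lowest of the three measured numbers in a functional assay on SK-MEL-28 cells (Homo sapiens) for inhibition, read by sulforhodamine B assay, with a stated time of 48 h (a higher number here means a weaker inhibitor of growth, a lower number a stronger inhibitor of growth), 1460 nM. Compound 2 `COc1cc(-c2nn(-c3cccc(NC(=O)c4cccc(C(F)(F)F)c4)c3)cc2-c2ccncc2)ccc1Cl` gives 2490 nM, a gap from compound 1 that lies within the scatter, while compound 3 `COc1cc(-c2nn(-c3cccc(NC(=O)c4ccccc4)c3)cc2-c2ccncc2)ccc1Cl` gives 3860 nM, a gap from compound 1 that lies beyond it. Compound 4 `O=C(Nc1cccc(-n2cc(-c3ccncc3)c(-c3ccc(Cl)c(O)c3)n2)c1)Nc1cccc(C(F)(F)F)c1` has not been measured; it differs from compound 1 in one place: 3-(trifluoromethyl)phenyl in place of 3,4-dichlorophenyl on an amide-type nitrogen. Within the data shown here, no measured pair shows this exact exchange. Among the measured compounds shown here, the only recorded step, a 1.6-fold higher number from compound 2 to compound 3 (0.19 log units; within the scatter), concerns a trifluoromethyl group at another site and was within the scatter, so it bears on the question only loosely. The expected step is therefore a 1.4-fold higher number from compound 1 to compound 4 (0.14 log units; within the scatter), with nothing beyond the scatter foreseen. Compound 4 is estimated at 2000 nM, within a range from 800 nM to 5000 nM.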

Compound 4, concentration for 50% growth inhibition: 4110 nM
Estimate against measurement, compound 4: 2.1-fold (0.31 log units) below; the range from low to high includes it.
By their numbers in this assay, from the lowest: compounds 1, 2, 3 and 4 (each within the scatter of the next, the first and the last beyond it).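

In this assay the exchange of 3,4-dichlorophenyl for 3-(trifluoromethyl)phenyl on an amide-type nitrogen gives a 2.8-fold higher number from compound 1 to compound 4 (0.45 log units; beyond the scatter) and so shows that growth inhibition responds to the group held at this position. The earlier trifluoromethyl step, a 1.6-fold higher number from compound 2 to compound 3 (0.19 log units; within the scatter) and at another site, lay within the scatter, whereas this one lies beyond it. Nothing at hand accounts for the step. The compounds shown leave open how a cyclohexyl group on this nitrogen, or a carboxylic acid on its aromatic ring, would compare.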